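A few compounds are considered here, and "the series" means these few. Any claim that something is new, unique, unknown or untested is made for them only; others in the source may bear on it.

Series notes. Compound 1 `CNC(=O)N1CCCc2ccc(NC(=O)c3ccc(-c4cc[nH]n4)cc3)cc21` and compound 2 `CNC(=O)N1CCCc2ccc(NC(=O)c3ccc(-c4ccncc4)cc3)cc21` share one core and differ only in the aryl group on the benzamide. In a functional assay on MV4-11 cells (Homo sapiens) for antiproliferative activity, with a stated time of 6 days, tested at 6.25 uM (a higher number here means a stronger effect of the compound at the concentration tested, a lower number a weaker effect), compound 1 gives 99.1%, while compound 2 gives 88.7%. For the measured compounds named here, the step of a number 10.4 percentage points lower from compound 1 to compound 2 (beyond the scatter) is the only measured step, and it places compound 2 as the lower of the two numbers seen so far in this assay.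

Compound 3 `CNC(=O)N1CCCc2ccc(NC(=O)c3ccc(-c4ccccn4)cc3)cc21` is the next member. Its change from compound 2 is pyridin-2-yl in place of pyridin-4-yl on an aromatic carbon, para to a large group. Going by the values given here, no measured step moves the ring nitrogen within a pyridine, so the single step from compound 1 to compound 2 bears on it only loosely, as a sign that this position tolerates a heteroaryl swap with a modest effect. The expected step is therefore a number 3.7 percentage points lower from compound 2 to compound 3 (within the scatter), within the scatter. Compound 3 is estimated at 85%, with a range of 65% to 98%.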

Compound 3, a percentage reported as inhibition, at one concentration (the size of the read-out at that concentration, not a potency): 79.2%
Compound 3: middle estimate off by 5.8 percentage points, on the high side; measured number inside the range.
By their numbers in this assay, from the lowest: compounds 3 and 2 (each within the scatter of the next); then compound 1.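

In this assay, shifting the ring nitrogen from pyridin-4-yl to pyridin-2-yl gives a number 9.5 percentage points lower from compound 2 to compound 3 (within the scatter) and so does not separate these two pyridine isomers at this place, para to a large group. Replacing 1H-pyrazol-3-yl with pyridin-2-yl gives a number 19.9 percentage points lower from compound 1 to compound 3 (beyond the scatter) and is the second pyridine swap to fall beyond the scatter, which leaves compound 1 the strongest of the three compounds, with no exception among them to the pyridines sitting lower. Nothing measured explains either step.

On these data alone, whether a pyridin-3-yl or a plain phenyl group would stand with the two pyridines or with compound 1 remains open. As far as these compounds go, the read-out comes from a single concentration, so how these compounds compare in potency also remains open.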